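The compounds below may be only part of what the source reports. "The series", "measured", "known", "first", "only" and "open" are said of these compounds alone.

Measured compounds:
- compound 1 `COC(=O)c1c(Nc2ccc(F)cc2)sc(C(=O)c2ccc(OC)cc2)c1C` — in a functional assay, with a stated time of 150 min, tested at 35 ug/mL (on this read-out lower numbers stand for a weaker effect and higher numbers for a stronger effect at the one concentration tested), compound 1 gives 25.6%
- compound 2 `COC(=O)c1c(Nc2ccc(F)cc2)sc(C(=O)c2ccc(C)cc2)c1C` — in this assay compound 2 gives "not active" (no number reported)

Going by the values given here, compound 1 is the only compound of this pair with a numerical read-out; compound 2 is recorded without a single number, so no step between the two can be sized, and their two entries are all that can be said of the pair. Within the numbers shown, compound 1 therefore stands alone as the reference point.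

Compound 3 `COc1ccc(C(=O)c2sc(Nc3ccc(F)cc3)c(C(=O)O)c2C)cc1` departs from compound 1 in one place: hydrogen in place of methyl on an oxygen next to a carbonyl group. The change sits on an oxygen next to a carbonyl group, and read one bond further out it is methoxy to hydroxy, or methoxycarbonyl to carboxy. Among the compounds with values here, nothing measured here speaks to such a change, so the expectation rests on the single value of compound 1 alone. The step is expected to be small, most likely a slight fall that does not clearly exceed the usual scatter, as a number 5.6 percentage points lower from compound 1 to compound 3 (within the scatter) expresses. Compound 3 is thus estimated at 20% in this assay, with a plausible range from 5% to 38%.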

Compound 3, a percentage reported as activity, at one concentration (the size of the read-out at that concentration, not a potency): 12.8%
For compound 3 the middle estimate is 7.2 percentage points above the measured one; the range from low to high includes it.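

Going by these compounds alone, the change from methoxycarbonyl to carboxy is the first step in this set that can be sized: in this assay, hydrogen in place of methyl on an oxygen next to a carbonyl group gives a number 12.8 percentage points lower from compound 1 to compound 3 (beyond the scatter). This shows that the read-out responds to what sits on this oxygen, yet the carboxy compound still gives a number rather than an entry without one, so the methyl is not needed for some effect to remain at the one concentration tested. No measurement at hand explains the fall, and the result stands as an observation only.

As far as these compounds go, with a single step at this place, it remains open whether the fall belongs to the loss of the methyl or to the carboxy group itself, and an ethyl ester or a primary amide in place of the methoxycarbonyl group would be needed to separate the two. Also open, from the compounds shown here alone, is whether the same step would hold with another group on the benzoyl ring, since the step between compound 1 and compound 2 cannot be read and the shared core has so far been varied in only these few ways.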